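Chloro to trifluoromethyl on the core: plasma unbound fraction

The source may report more compounds than this note shows. Statements on the series, on what has been measured and on what is new or still open speak of the compounds shown alone.

Working notes on the series. Compound 1 `COc1c(F)ccc(F)c1C1CCN(c2ccn3c(CC4CC4)nnc3c2Cl)CC1` gives < 0.01 in an ADME assay on a cell-free system (plasma, Rattus norvegicus) for protein binding (a lower number here means a smaller unbound share, a higher number a larger unbound share of the compound), which is a limit of the assay and not a number. Compound 2 `COc1ccc(F)c(F)c1C1CCN(c2ccn3c(CC4CC4)nnc3c2Cl)CC1` gives < 0.01 in this assay, again a limit. Compound 3 `COc1cc(F)cc(F)c1C1CCN(c2ccn3c(CC4CC4)nnc3c2Cl)CC1` gives < 0.01 in this assay, also a limit. Compound 1 thus stands at the limit of < 0.01 in this assay, at which 3 of the 3 values shown sit, and the steps among the three aryl variants, a step that the two limits leave unreadable from compound 1 to compound 2, a step that the two limits leave unreadable from compound 1 to compound 3 and a step that the two limits leave unreadable from compound 2 to compound 3, cannot be sized; the three difluoro-methoxyphenyl patterns on the saturated ring carbon leave no readable difference.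

Compound 4 `COc1c(F)ccc(F)c1C1CCN(c2ccn3c(CC4CC4)nnc3c2C(F)(F)F)CC1` differs from compound 1 by trifluoromethyl in place of chloro on an aromatic carbon. Within the data shown here, none of the measured steps concerns this position on the core; all three vary the aryl group, and all sit at the limit, so they give no scale for the chloro-to-trifluoromethyl exchange in this assay. The only footing is that every measured member of the series has so far reported a limit. On that basis the unbound share of compound 4 is expected to remain at the limit in this assay. The step that the limit leaves unreadable from compound 1 to compound 4 is therefore expected to be unreadable rather than a measurable change. The estimate for compound 4 is 0.005, with a range from 0.002 to 0.012.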

Compound 4, unbound fraction: < 0.01
Compound 4 ended at the assay's limit; the forecaster's own chance of this, stated with the estimate: 85%; the middle value is on the limit's open side.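

Compound 4 gives < 0.01 in this assay as a limit of the assay and not a number. With compound 1 also at a limit, no step can be read between compound 1 and compound 4. The compounds shown leave open how large any unbound fraction is and whether trifluoromethyl in place of chloro changes it: the limit of < 0.01 in this assay, at which 4 of the 4 values shown sit.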